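The compounds below may be only part of what the source reports. "The series", "measured", "known", "first", "only" and "open" are said of these compounds alone.

The compounds here share one core and differ in the groups at its two ends. In a functional assay on HL-60 cells (Homo sapiens) for inhibition, read by CCK-8 assay, with a stated time of 48 h, tested at 20 uM (a higher number here means more inhibition of growth at the concentration tested, a lower number less inhibition of growth), compound 1 (`COc1ccc(Cc2nnc(NC(=O)/C(C#N)=C/c3ccccc3OS(=O)(=O)c3ccc(C)cc3)s2)cc1`) gives 25% as its result, and compound 3 (`N#C/C(=C\c1ccccc1OS(=O)(=O)c1ccc(F)cc1)C(=O)Nc1nnc(Cc2ccc(F)cc2)s1`) gives 13% as its result. Compound 2 (`Cc1ccc(S(=O)(=O)Oc2ccccc2/C=C(\C#N)C(=O)Nc2nnc(Cc3ccc(F)cc3)s2)cc1`) has no single number: it is recorded as "not active" (no number reported) in this test, so its standing can only be given in those words.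

Compound 4 (`Cc1ccc(Cc2nnc(NC(=O)/C(C#N)=C/c3ccccc3OS(=O)(=O)c3ccc(C)cc3)s2)cc1`) has not been measured yet. It differs from compound 2 by one small edit (methyl in place of fluoro on an aromatic carbon), with methyl in place of fluoro on an aromatic carbon, para to a large group, turning 4-fluorobenzyl into 4-methylbenzyl.

Among the compounds with values here, no measured pair shows a change of this kind, and compound 2 offers no number to start from, so any step can only be a rough expectation. A small upward step in this assay is expected, about the size of the usual scatter or slightly more. With compound 2 recorded as "not active" (no number reported) and compound 1 at 25% in the same test, weak growth inhibition is the expected outcome, and a result without a number remains possible. For compound 4 the estimated value is 15% with an expected range from 0% to 35% in this test.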

Compound 4, percent growth inhibition at one concentration: 17%
The estimate for compound 4 lay 2 percentage points below the measured number, within the range that was stated.
By their numbers in this assay, from the lowest: compounds 3, 4 and 1 (each within the scatter of the next, the first and the last beyond it).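

In this assay, exchanging methoxy for methyl gives a number 8 percentage points lower from compound 1 to compound 4 (within the scatter) and so does not separate these two groups at this position. The new result also gives this position a second number: compound 4, with its 4-methylbenzyl group, gives 17%, while compound 2, with its 4-fluorobenzyl group, stands as "not active" (no number reported), and the size of that step cannot be read. No measurement of any property of these groups accompanies the result, so the data offer no explanation for these readings.

Fluoro, methyl and methoxy are the only groups shown at this position, so it remains open whether an amine, a carboxylic acid or a longer chain such as butoxy there would change growth inhibition by more than the usual scatter. Within the data shown here, it also remains open how far the other end of the molecule matters, since no measured pair isolates a change there, and a group such as a methoxy or a chloro on that far aromatic ring could be informative.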